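A few compounds are considered here, and "the series" means these few. Any claim that something is new, unique, unknown or untested is made for them only; others in the source may bear on it.

Measured compounds:
Compound 1, `CCCn1c(=O)c2nc(C3CCCC(NC(C)=O)C3)[nH]c2n(CCC)c1=O`, gives 41 nM in a functional assay for antagonist activity at adenosine receptor A1 (Homo sapiens); on this read-out lower numbers stand for stronger inhibition and higher numbers for weaker inhibition.
Compound 2, `CCCn1c(=O)c2nc([C@H]3CC[C@H](CNC(C)=O)CC3)[nH]c2n(CCC)c1=O`, gives 8 nM in this assay.
Compound 3, `CCCn1c(=O)c2nc(C3CCC3C(=O)O)[nH]c2n(CCC)c1=O`, gives 660 nM in this assay.

Compound 3 stands at the highest number of the three, which on this read-out means the weakest inhibition. Its gap to compound 1 and its larger gap to compound 2 both lie beyond the usual scatter, so compound 3 is the least potent of the measured set.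

Compound 4, `CCCn1c(=O)c2nc(C3CC3C)[nH]c2n(CCC)c1=O`, has not been measured yet. It differs from compound 3 in one place: 2-methylcyclopropyl in place of 2-carboxycyclobutyl on an aromatic carbon. The group that enters is smaller and carries no hydrogen-bond donor or acceptor, while the group that leaves carries one of each. Going by the values given here, no measured pair shows this exact change, so the size of the step must be estimated. Given that compound 1 and compound 2, which also lack an acid on their ring, give lower numbers than compound 3, the expectation is that compound 4 gives a lower number as well, with a step of an 11-fold lower number from compound 3 to compound 4 (1.04 log units; beyond the scatter) that is expected to exceed the scatter. Compound 4 is estimated at 60 nM, within a range from 12 nM to 300 nM.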

Compound 4, inhibition constant: 11 nM
Estimate against measurement, compound 4: 5.5-fold (0.74 log units) above; measured number below the stated range.
By their numbers in this assay, from the lowest: compounds 2 and 4 (each within the scatter of the next); then compound 1; then compound 3.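

In this assay, putting 2-methylcyclopropyl in place of 2-carboxycyclobutyl on this aromatic carbon, between two ring nitrogen atoms, gives a 60-fold lower number from compound 3 to compound 4 (1.78 log units; beyond the scatter), a large step. It shows that the carboxylic acid is not needed at this position for strong inhibition, as compound 4 reaches 11 nM with a group that has no hydrogen-bond donor or acceptor. The data offer no measured explanation for the size of this step.

The change alters the ring size, removes the carboxylic acid and adds a methyl all at once, so the step cannot be divided among these three differences. A 2-methylcyclobutyl group and a 2-carboxycyclopropyl group would help to separate them, while an amine on the small ring remains an open case.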